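Branching the Pentyl Chain: From Compound 2 to Compound 3

A few compounds are considered here, and "the series" means these few. Any claim that something is new, unique, unknown or untested is made for them only; others in the source may bear on it.

Of the compounds shown here, two have been measured so far in an assay for inhibition of beta-galactosidase (Homo sapiens), read by fluorescence, with a stated time of 30 min, at pH 4.5; a higher number here means a weaker inhibitor, a lower number a stronger inhibitor. Compound 1 `CCCCCCCCN[C@@H]1C=C(C)[C@H](O)[C@H](O)[C@H]1O` gives 46000 nM in this assay. Compound 2 `CCCCCN[C@@H]1C=C[C@H](O)[C@H](O)[C@H]1O` gives 19000 nM in this assay, the lower of the two numbers, and its gap to compound 1 lies beyond the usual scatter of repeated measurements. Compound 3 `CC(C)CCN[C@@H]1C=C[C@H](O)[C@H](O)[C@H]1O` has not yet been measured. It differs from compound 2 in a single place: isopropyl in place of propyl on a saturated chain carbon, two bonds along the chain from an amine nitrogen. The two structures hold the same atoms joined differently, the chain being branched on a saturated chain carbon, two bonds along the chain from an amine nitrogen. Within the data shown here, no step between measured compounds resembles this change, so there is no direct precedent. For a rearrangement this modest, a step in this assay within the usual scatter, in either direction, is expected. Compound 3 is therefore estimated at 19000 nM in this assay, with a range from 8000 nM to 45000 nM. The step expected from compound 2 to compound 3 is no change at the digits printed from compound 2 to compound 3 (within the scatter).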

Compound 3, half-maximal inhibitory concentration: 28000 nM
Beside the measured number, compound 3's estimate is 1.5-fold (0.17 log units) below it, and the stated range covers the measured number.
By their numbers in this assay, from the lowest: compounds 2, 3 and 1 (each within the scatter of the next, the first and the last beyond it).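

In this assay, among these compounds, isopropyl in place of propyl on a saturated chain carbon, two bonds along the chain from an amine nitrogen, gives a 1.5-fold higher number from compound 2 to compound 3 (0.17 log units; within the scatter), the first step between measured compounds that differ in one place. At this position, then, going from pentyl to isopentyl leaves a change that cannot be told from the scatter, so compound 2 and compound 3 read as equal here. Nothing shown offers an explanation for this result.

The compounds shown leave open whether a larger branch at this carbon, such as tert-butyl, or a phenyl ring at the end of the chain would give a step beyond the scatter. They also cannot separate the longer octyl chain of compound 1 from the methyl group on its core, since the two differences occur together.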